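Carbamoyl in Place of Cyano: Expectation for Compound 4

The source may hold more compounds than are shown below. What is called first, only, known or untested is meant among the compounds shown, and "the series" means these compounds.

Of the compounds shown here, three on a shared core have been measured in an assay on isolated protein for inhibition of 2-Hydroxyacid oxidase 2 (Rattus norvegicus); a higher number here means a weaker inhibitor, a lower number a stronger inhibitor. Compound 1 `Cc1n[nH]c(C(=O)O)c1Cc1cccc(-c2cccc(F)c2)c1` gives 500 nM, compound 2 `Cc1n[nH]c(C(=O)O)c1Cc1cccc(-c2ccc(OC(F)(F)F)cc2)c1` gives 300 nM, and compound 3 `Cc1n[nH]c(C(=O)O)c1Cc1cccc(-c2ccc(C#N)cc2)c1` gives 300 nM. Compound 3 stands level with compound 2 and together they hold the lowest numbers of the three; the step of a 1.7-fold lower number from compound 1 to compound 3 (0.22 log units; within the scatter) and the step of no change at the digits printed from compound 2 to compound 3 (within the scatter) are both within the scatter, so the three compounds cannot be separated in this assay.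

Compound 4 `Cc1n[nH]c(C(=O)O)c1Cc1cccc(-c2ccc(C(N)=O)cc2)c1` is the next member: carbamoyl in place of cyano on an aromatic carbon. Neither measured step involves carbamoyl, so none bears directly on it. The nearest guide is the step of no change at the digits printed from compound 2 to compound 3 (within the scatter), where exchanging one group for another left the number unchanged, and the step of a 1.7-fold lower number from compound 1 to compound 3 (0.22 log units; within the scatter), also within the scatter. He therefore expects no shift beyond the scatter, the step of no change at the digits printed from compound 3 to compound 4 (within the scatter) being the estimate. In this assay compound 4 is estimated at 300 nM, with a range from 120 nM to 800 nM.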

Compound 4, half-maximal inhibitory concentration: 200 nM
For compound 4 the middle estimate is 1.5-fold (0.18 log units) above the measured one; low and high end bracket the measured number.
By their numbers in this assay, from the lowest: compounds 4, 2, 3 and 1 (each within the scatter of the next, the first and the last beyond it).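

On an aromatic carbon para to a large group, the carbamoyl of compound 4 adds a hydrogen-bond donor that cyano lacks, yet this assay shows a 1.5-fold lower number from compound 3 to compound 4 (0.18 log units; within the scatter). For the compounds shown here, the exchange for trifluoromethoxy gives a 1.5-fold lower number from compound 2 to compound 4 (0.18 log units; within the scatter), so this place now holds three groups, including the first with a hydrogen-bond donor, with no step among compounds 2, 3 and 4 beyond the scatter. No supporting measurement accompanies these numbers to explain them.

From the compounds shown here alone, whether a carboxylic acid, an amine or a methylcarbamoyl group on the same carbon would also stay within the scatter remains open. So does whether carbamoyl would give a similar number on another carbon of that ring.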